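Predicting a para-chloro analogue from three measured amides

This account rests on a few compounds, and the source may have more. Where it says the series, first, only, none or still open, it means among the compounds named here.

Measured so far in a functional assay on MCF7 cells (Homo sapiens) for cytotoxicity, read by MTT assay, with a stated time of 72 h; a higher number here means a weaker inhibitor, a lower number a stronger inhibitor:
compound 1 `Cc1ccc(-c2ccnc(C(=O)Nc3ccc(Oc4ccnc5[nH]ccc45)c(F)c3)n2)cc1` gives 7170 nM;
compound 2 `O=C(Nc1ccc(Oc2ccnc3[nH]ccc23)c(F)c1)c1nccc(-c2cccc(Cl)c2)n1` gives 1580 nM;
compound 3 `COc1ccc(-c2ccnc(C(=O)Nc3ccc(Oc4ccnc5[nH]ccc45)c(F)c3)n2)cc1` gives 8960 nM.

Compound 3 has the highest number of the three, so it is the weakest inhibitor measured, although its gap to compound 1 lies within the scatter and only its gap to compound 2 is a real difference. Compound 4 `O=C(Nc1ccc(Oc2ccnc3[nH]ccc23)c(F)c1)c1nccc(-c2ccc(Cl)cc2)n1` is not yet measured. It differs from compound 3 by chloro in place of methoxy on an aromatic carbon. Within the data shown here, two measured steps bear on this. The step of a 4.5-fold lower number from compound 1 to compound 2 (0.66 log units; beyond the scatter) shows that bringing in a chloro-bearing phenyl, there as 3-chlorophenyl, gives a clearly lower number; the step of a 5.7-fold higher number from compound 2 to compound 3 (0.75 log units; beyond the scatter) shows the reverse, a clearly higher number on going back to a methoxy-bearing phenyl. The step of a 1.2-fold higher number from compound 1 to compound 3 (0.10 log units; within the scatter) shows that methyl and methoxy behave alike. A chloro group at the place named in the difference has not been tested, so the size is uncertain, but a lower number is expected. Compound 4 is therefore estimated at 3000 nM, within 1200 nM to 8000 nM, an expected step of a 3.0-fold lower number from compound 3 to compound 4 (0.48 log units; beyond the scatter).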

Compound 4, half-maximal inhibitory concentration: 9660 nM
Beside the measured number, compound 4's estimate is 3.2-fold (0.51 log units) below it, and the stated range ends below it.
By their numbers in this assay, from the lowest: compound 2; then compounds 1, 3 and 4 (each within the scatter of the next).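

In this assay, a chlorine on the phenyl ring does not by itself give a lower number: a 1.1-fold higher number from compound 3 to compound 4 (0.03 log units; within the scatter) and a 1.3-fold higher number from compound 1 to compound 4 (0.13 log units; within the scatter) leave 4-chlorophenyl level with the methoxy and methyl analogues. What matters among these compounds is where the chlorine sits, since a 6.1-fold higher number from compound 2 to compound 4 (0.79 log units; beyond the scatter) separates the two chloro isomers, and only compound 2 stands apart from the rest. Nothing measured here explains why the two chlorine placements differ.

On these data alone, it remains open whether a methyl or methoxy group placed where compound 2 carries its chlorine would match compound 2, which would tie the lower number to the place rather than to chloro. As far as these compounds go, it is also open how an amine or a carboxylic acid would behave at the place of the chloro in compound 4.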